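Replacing cyanomethyl with prop-1-yn-1-yl on the amide chain

A few compounds are considered here, and "the series" means these few. Any claim that something is new, unique, unknown or untested is made for them only; others in the source may bear on it.

Of the compounds shown here, two built on the shared core have been measured in a functional assay on MIA PaCa-2 cells (Homo sapiens) for antiproliferative activity; on this read-out higher numbers stand for an effect only at larger amounts of compound and lower numbers for an effect already at smaller amounts. Compound 1 `Cc1cc2c(C(=O)NCC#N)cccc2n1-c1nc2c(c(NCc3ccccc3)n1)CCCC2` gives 468 nM, and compound 2 `Cc1cc2c(C(=O)NCCC#N)cccc2n1-c1nc2c(c(NCc3ccccc3)n1)CCCC2` gives 517 nM. Compound 2 thus has a single neighbour on the numbers, and the two values lie within the scatter of each other.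

Compound 3 `CC#CCNC(=O)c1cccc2c1cc(C)n2-c1nc2c(c(NCc3ccccc3)n1)CCCC2` is still unmeasured. Its difference from compound 2 is this: prop-1-yn-1-yl in place of cyanomethyl on a saturated chain carbon bound to an amide-type nitrogen. The triple bond stays, but prop-1-yn-1-yl stands in place of cyanomethyl on a saturated chain carbon bound to an amide-type nitrogen, so the nitrile is gone.

Going by the values given here, the only measured step that bears on this change is a 1.1-fold higher number from compound 1 to compound 2 (0.04 log units; within the scatter). It shows that the number held when the chain was altered at this place. Among the compounds with values here, no measured step removes the nitrile, however, so the range has to stay wide. No shift beyond the scatter is expected in this assay. The estimated step is a 1.1-fold lower number from compound 2 to compound 3 (0.03 log units; within the scatter). Compound 3 is expected at 480 nM, with an estimated range from 200 nM to 1200 nM.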

Compound 3, half-maximal effective concentration: 723 nM
Estimate against measurement, compound 3: 1.5-fold (0.18 log units) below; the measured number falls inside the stated range.
By their numbers in this assay, from the lowest: compounds 1, 2 and 3 (each within the scatter of the next).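

Unlike compound 1 and compound 2, compound 3 carries no nitrile, and in this assay the exchange of cyanomethyl for prop-1-yn-1-yl on a saturated chain carbon bound to an amide-type nitrogen gives a 1.4-fold higher number from compound 2 to compound 3 (0.15 log units; within the scatter) at this place. The same holds against the shorter nitrile side chain, with a 1.5-fold higher number from compound 1 to compound 3 (0.19 log units; within the scatter) for the change from cyano to prop-1-yn-1-yl, so the nitrile nitrogen, with the one hydrogen-bond acceptor counted in the leaving group, can be lost here without a step beyond the scatter. Nothing measured on these compounds speaks to why the three numbers lie so close together.

Going by these compounds, it remains open whether this place accepts groups of a different kind, such as an amine or a carboxylic acid at the end of the chain, or a longer chain. Also open, on these data alone, is whether the exchange of cyanomethyl for prop-1-yn-1-yl would read the same way on another core or in another cell line.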